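Lengthening the acid chain of compound 2

This account rests on a few compounds, and the source may have more. Where it says the series, first, only, none or still open, it means among the compounds named here.

Measured so far:
compound 1 (`Nc1nc2[nH]c(CCCCCC(=O)N[C@@H](CCC(=O)O)C(=O)O)cc2c(=O)[nH]1`) : > 1000 nM
compound 2 (`Nc1nc2[nH]c(CCCCCCC(=O)O)cc2c(=O)[nH]1`) : > 1000 nM

In a functional assay on PC43-10 cells (Cricetulus griseus) for inhibition, read by CellTiter-Blue, with a stated time of 96 h (on this read-out higher numbers stand for weaker inhibition and lower numbers for stronger inhibition), compound 2 gives only a limit and not a number. Going by the values given here, it sits at the limit of > 1000 nM in this assay, at which 2 of the 2 values shown sit, and compound 1 sits there as well, so the measured compounds offer no step to read.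

The next compound is compound 3 (`Nc1nc2[nH]c(CCCCCCCCC(=O)O)cc2c(=O)[nH]1`). The change is 2-carboxyethyl in place of carboxy on a saturated chain carbon, six bonds along the chain from an aromatic carbon.

The only reference for the expectation is compound 2 at > 1000 nM, which is a limit. No change beyond the scatter is expected, and the estimate is a number no higher from compound 2 to compound 3 (the limit leaves the size open) in this assay. Compound 3 is expected near 1000 nM, with an estimated range of 300 nM to 3000 nM, and another report as a limit is likely.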

Compound 3, half-maximal inhibitory concentration: > 1000 nM
Compound 3 was reported as a limit; the forecaster's own chance of this, stated with the estimate: 85%; the middle value sits exactly at the limit.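

No step can be read from compound 2 to compound 3: in this assay compound 3 gives > 1000 nM, which is a limit, as is the value of compound 2. The compounds shown leave open whether 2-carboxyethyl in place of carboxy changes inhibition at all.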